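Cytotoxicity notes: from compound 3 to compound 4

The source may hold more compounds than are shown below. What is called first, only, known or untested is meant among the compounds shown, and "the series" means these compounds.

Measured in an ADME assay on BHK cells (Mesocricetus auratus) for cytotoxicity, read by MTT assay; on this read-out higher numbers stand for lower toxicity in this test and lower numbers for higher toxicity in this test:
- Compound 1 `OC[C@@H]1[C@@H](O)[C@H](O)[C@@H](O)CN1CCCCCCOc1cc(F)ccc1F`: > 500000 nM, a limit.
- Compound 2 `COc1ccc(OCCCCCCN2C[C@H](O)[C@@H](O)[C@H](O)[C@H]2CO)cc1`: > 500000 nM, a limit.
- Compound 3 `CCC1CCC(OCCCCCCN2C[C@H](O)[C@@H](O)[C@H](O)[C@H]2CO)CC1`: 475000 nM.

Among the compounds with values here, compound 3 gives 475000 nM, the only number in the set. The rest is the limit of > 500000 nM in this assay, at which 2 of the 3 values shown sit.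

Compound 4 `CC1CCC(OCCCCCCN2C[C@H](O)[C@@H](O)[C@H](O)[C@H]2CO)CC1C` differs from compound 3 by a group of 8 heavy atoms (8 carbon; one six-membered non-aromatic ring of carbon only) in place of a group of 8 heavy atoms (8 carbon; one six-membered non-aromatic ring of carbon only), on an oxygen on a saturated carbon. The two have the same atoms, joined differently, and the change sits on an oxygen on a saturated carbon.

Within the data shown here, two measured steps bear on this change: an at least 1.0-fold lower number from compound 1 to compound 3 (0.02 log units; that floor lies within the scatter), and an at least 1.0-fold lower number from compound 2 to compound 3 (0.02 log units; that floor lies within the scatter). Both are only floors, and both lie within the scatter. The remaining one, a step that the two limits leave unreadable from compound 1 to compound 2, gives no size. With no readable step beyond the scatter, none is expected in this assay, in either direction. The expected step is a 1.1-fold lower number from compound 3 to compound 4 (0.02 log units; within the scatter). A report of only a limit remains possible for compound 4. For compound 4 the estimated value is 450000 nM, with an expected range from 250000 nM to 700000 nM.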

Compound 4, half-maximal cytotoxic concentration: > 500000 nM
Compound 4 was reported as a limit; the forecaster's own chance of this, stated with the estimate: 40%; middle value at least 1.1-fold (0.04 log units) from the limit.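

Joining the same atoms differently in the group on an oxygen on a saturated carbon gives an at least 1.0-fold higher number from compound 3 to compound 4 (0.02 log units; that floor lies within the scatter) in this assay. That figure is only a floor, and the steps from compound 1 and compound 2 to compound 4 cannot be read. Among the earlier compounds, only compound 3 held a six-membered non-aromatic ring of carbon only, and it alone gave a number; compound 4 shows that such a ring can also end at the limit: the limit of > 500000 nM in this assay, at which 3 of the 4 values shown sit.

On these data alone, how far the true values of compound 1, compound 2 and compound 4 lie past that limit stays open, so no order among them can be given. Also open, as far as these compounds go, is how the read-out would respond to an amine or a carboxylic acid on this group, or to a longer chain in its place.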